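Ester for Methyl on the Alkene of Compound 1

The source may report more compounds than this note shows. Statements on the series, on what has been measured and on what is new or still open speak of the compounds shown alone.

Measured so far:
compound 1, `CC=C(c1cc(OC)cc(OC)c1)c1ccc(OC)c(OC)c1`, 480 nM
compound 2, `COc1cc(OC)cc(C(=CC#N)c2ccc(OC)c(NC(C)=O)c2)c1`, 92 nM
compound 3, `CC=C(c1cc(OC)cc(OC)c1)c1ccc(OC)c(O)c1`, 30 nM

In a functional assay on HCT-116 cells (Homo sapiens) for cytotoxicity, read by scintillation counting and thymidine incorporation, with a stated time of 72 h (on this read-out lower numbers stand for stronger inhibition and higher numbers for weaker inhibition), compound 1 stands highest of the three numbers. Compound 3 lies furthest from it, with the change from compound 1 to compound 3 giving a 16-fold lower number from compound 1 to compound 3 (1.20 log units; beyond the scatter); compound 2 is the nearest, beyond the scatter.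

Compound 4 `COC(=O)C=C(c1cc(OC)cc(OC)c1)c1ccc(OC)c(OC)c1` differs from compound 1 by methoxycarbonyl in place of methyl on a double-bonded chain carbon bound to a double-bonded chain carbon. Among the compounds with values here, the only step in hand, a 16-fold lower number from compound 1 to compound 3 (1.20 log units; beyond the scatter), is on an aromatic ring, not on the chain, so it does not bear on this change. Compound 2 carries a different chain group but also differs on a ring, so only its value is known. Within the data shown here, no step guides this change; no shift beyond the scatter is expected, with wide uncertainty. Compound 4 is expected at 400 nM (range 100 nM to 1600 nM), a step of a 1.2-fold lower number from compound 1 to compound 4 (0.08 log units; within the scatter).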

Compound 4, half-maximal inhibitory concentration: > 10000 nM
Compound 4: only a limit was reported; the forecaster's own chance of this, stated with the estimate: 5%; middle value at least 25-fold (1.39 log units) from the limit.
By their numbers in this assay, from the lowest: compound 3; then compound 2; then compound 1. At a limit, above all of these: compound 4.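

In this assay, within the data shown here, methoxycarbonyl in place of methyl on a double-bonded chain carbon bound to a double-bonded chain carbon gives an at least 20-fold higher number from compound 1 to compound 4 (1.31 log units; beyond the scatter), the first step read at this position, as the only earlier step lay on an aromatic ring. The value of compound 4 is a limit: the limit of > 10000 nM in this assay, at which 1 of the 4 values shown sits.

The chain position is therefore not indifferent to what it carries, at least for this one change.

Still open, going by these compounds, is how a carboxylic acid or an ethyl group on the same chain carbon would read. Also open, on these data alone, is whether the step from compound 1 to compound 3 would hold with methoxycarbonyl on the chain.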